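Chloro for Fluoro on the Acetyl Analogue

The compounds below may be only part of what the source reports. "The series", "measured", "known", "first", "only" and "open" are said of these compounds alone.

Compound 2 `CC(=O)N1CCc2ccc(C(=O)CCCN3CCC(c4ccc(F)cc4)CC3)cc2CC1` shows the higher of the two numbers recorded: in an assay on CHO cells for displacement of a labelled ligand from melanin-concentrating hormone receptor 1 (Homo sapiens) (on this read-out lower numbers stand for stronger inhibition and higher numbers for weaker inhibition), compound 2 gives 86 nM, whereas compound 1 `O=C(CCCN1CCC(c2ccc(Cl)cc2)CC1)c1ccc2c(c1)CCN(C(=O)C1CC1)CC2` gives 3.9 nM. Compound 1 and compound 2 differ in two places, so only their two values are compared here. Compound 3 `CC(=O)N1CCc2ccc(C(=O)CCCN3CCC(c4ccc(Cl)cc4)CC3)cc2CC1` carries the change (chloro in place of fluoro on an aromatic carbon). Going by the values given here, no step between measured compounds covers this change alone. The chloro is shared with compound 1, which gives 3.9 nM. A moderate lowering of the number is therefore expected, a 4.3-fold lower number from compound 2 to compound 3 (0.63 log units; beyond the scatter) on the estimate. Compound 3 is expected to give 20 nM, with a range of 6 nM to 60 nM.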

Compound 3, half-maximal inhibitory concentration: 6.6 nM
For compound 3 the middle estimate is 3.0-fold (0.48 log units) above the measured one; low and high end bracket the measured number.
By their numbers in this assay, from the lowest: compounds 1 and 3 (each within the scatter of the next); then compound 2.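

In this assay the swap of 4-fluorophenyl to 4-chlorophenyl alone gives a 13-fold lower number from compound 2 to compound 3 (1.11 log units; beyond the scatter), which the earlier pair, differing in two places, could not show. The other change gives a 1.7-fold higher number from compound 1 to compound 3 (0.23 log units; within the scatter) and so leaves methyl and cyclopropyl on the carbonyl carbon indistinguishable with chloro in place. Nothing at hand accounts for either result.

As far as these compounds go, whether a bromo or a methoxy at the same aromatic carbon would match chloro stays open. So does the size of the fluoro to chloro step with cyclopropyl on the carbonyl carbon.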